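The compounds below may be only part of what the source reports. "The series", "measured", "known", "first", "only" and "open" are said of these compounds alone.

Series notes. Compound 1 `CCN(CC)c1nc(Nc2cccc(C(=O)O)c2)nc(OC(C(F)(F)F)C(F)(F)F)n1` and compound 2 `CCN(CC)c1nc(Nc2cccc(F)c2)nc(OC(C(F)(F)F)C(F)(F)F)n1` share one core; compound 3 `CCN(CC)c1nc(Nc2ccc(C(=O)O)cc2)nc(OCC(F)(F)C(F)F)n1` and compound 4 `CCN(CC)c1nc(Nc2ccc(F)cc2)nc(OCC(F)(F)C(F)F)n1` share another, and the difference between the two cores is not broken down here. In an assay on cells for activation of Cystic fibrosis transmembrane conductance regulator (Homo sapiens), read by fluorescence, with stated times of 10 min and 12 s (a higher number here means that more compound is needed for the effect, a lower number that less compound is needed), compound 1 gives 160 nM and compound 2 gives 140 nM; the step of a 1.1-fold lower number from compound 1 to compound 2 (0.06 log units; within the scatter) goes with the change (fluoro in place of carboxy on an aromatic carbon). In this assay compound 3 gives 2500 nM, the highest number of the three measured; its gap to compound 1 and to compound 2 lies beyond the scatter, although no single-point difference from either is counted. Compound 4 is not yet measured. It differs from compound 3 by fluoro in place of carboxy on an aromatic carbon — the same kind of change as between compound 1 and compound 2, though there the fluoro stands meta to a large group and here para to a large group. Because the measured instance a 1.1-fold lower number from compound 1 to compound 2 (0.06 log units; within the scatter) stayed within the scatter, the step of a 1.3-fold lower number from compound 3 to compound 4 (0.10 log units; within the scatter) is expected to be small as well. Compound 4 is therefore estimated at 2000 nM in this assay, with an expected range from 700 nM to 6000 nM.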

Compound 4, half-maximal effective concentration: 4800 nM
The estimate for compound 4 lay 2.4-fold (0.38 log units) below the measured number, and the stated range covers the measured number.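

In this assay, fluoro in place of carboxy gives a 1.9-fold higher number from compound 3 to compound 4 (0.28 log units; within the scatter). Set beside the same change on the core of compound 1, the two steps cannot be told apart, so in this small set the change carries from one core to the other without a detectable difference: the same change on two cores in this assay, a 1.1-fold lower number (0.06 log units; within the scatter) from compound 1 to compound 2 and a 1.9-fold higher number (0.28 log units; within the scatter) from compound 3 to compound 4, 2.2-fold (0.34 log units) apart, within the scatter of two such steps. Going by these compounds alone, this agreement rests on only two pairs and does not show that the change would behave the same way on any further core, nor does it explain why replacing carboxy with fluoro leaves the number within the scatter on both cores.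

Still open, going by these compounds, is whether other groups at this aromatic carbon, such as an amine, a nitrile or a methoxy group, would also leave the number within the scatter. On these data alone, the separate contribution of the difference between the two cores also remains open, as does the effect of a longer chain on the ether oxygen.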